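This account rests on a few compounds, and the source may have more. Where it says the series, first, only, none or still open, it means among the compounds named here.

Measured compounds:
Compound 1 `O=C(Nc1ccccc1)C(Cl)Cl` gives 130000 nM in a functional assay on A549 cells (Homo sapiens) for antiproliferative activity, read by MTT assay, with a stated time of 72 h; a higher number here means a weaker inhibitor, a lower number a stronger inhibitor.
Compound 2 `O=C(Nc1cccc(Br)c1)C(Cl)Cl` gives 7800 nM in this assay.

For the measured compounds named here, compound 2 carries the lowest number of the two; its nearest neighbour is compound 1, and the step of a 17-fold lower number from compound 1 to compound 2 (1.22 log units; beyond the scatter) is the only step measured so far.

Compound 3 `N#Cc1cccc(NC(=O)C(Cl)Cl)c1` is not yet measured. It differs from compound 2 by cyano in place of bromo on an aromatic carbon. Going by the values given here, no measured step exchanges one substituent for another at this place; the single measured step, a 17-fold lower number from compound 1 to compound 2 (1.22 log units; beyond the scatter), puts bromo in for hydrogen there and so bears only indirectly on the present change. Whether cyano carries the same weight as bromo cannot be read from two compounds. The expectation for compound 3 is a number between those of compound 1 and compound 2, nearer compound 2, with wide uncertainty. Compound 3 is estimated at 15000 nM in this assay, range 4000 nM to 60000 nM. This estimate means an expected step of a 1.9-fold higher number from compound 2 to compound 3 (0.28 log units; within the scatter).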

Compound 3, half-maximal inhibitory concentration: 66500 nM
The estimate for compound 3 lay 4.4-fold (0.65 log units) below the measured number; measured number above the stated range.
By their numbers in this assay, from the lowest: compound 2; then compounds 3 and 1 (each within the scatter of the next).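

Not every group in place of hydrogen at this aromatic carbon carries the gain seen with bromo: in this assay, cyano in place of bromo gives an 8.5-fold higher number from compound 2 to compound 3 (0.93 log units; beyond the scatter), a step beyond the scatter. Cyano in place of hydrogen gives a 2.0-fold lower number from compound 1 to compound 3 (0.29 log units; within the scatter), so at this place cyano cannot be told apart from hydrogen, and of the two groups tried only bromo separates from the unsubstituted core of compound 1. Nothing on hand accounts for the difference between the two groups.

Whether the gain is particular to bromo remains open, since chloro, iodo, methyl, methoxy and an amine at this carbon do not appear among the compounds shown. Also open, on these data alone, is whether bromo would keep its step at another carbon of the ring.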